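A few compounds are considered here, and "the series" means these few. Any claim that something is new, unique, unknown or untested is made for them only; others in the source may bear on it.

Among the measured compounds shown here, compound 1 `Cc1cccc2cc(/C=C3\SC(=S)N(CC(=O)O)C3=O)c(Cl)nc12` is one of two compounds measured here. In a toxicity assay on THP-1 cells (Homo sapiens) for cytotoxicity, read by MTT assay, with a stated time of 48 h (a lower number here means a stronger inhibitor of growth, a higher number a weaker inhibitor of growth), compound 1 gives > 100 ug/mL, which is a limit of the assay rather than a number. A related compound, compound 2 `O=C(O)CN1C(=O)/C(=C/c2cc3cc(F)ccc3nc2Cl)SC1=S`, was measured in the same way. In this assay compound 2 gives > 100 ug/mL, also a limit. Both values sit at the limit of > 100 ug/mL in this assay, at which 2 of the 2 values shown sit, so compound 1 stands exactly where the other measured compound stands, with no number to separate the two.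

Compound 3 `Cc1cccc2cc(/C=C3\SC(=S)NC3=O)c(Cl)nc12` has not been measured. It differs from compound 1 in one place: hydrogen in place of carboxymethyl on an amide-type nitrogen in a ring. For the measured compounds named here, no step between two measured compounds covers such a change, so its size has no measured counterpart. The step that the limit leaves unreadable from compound 1 to compound 3 is expected to stay within the scatter. Compound 3 is therefore expected to give about 150 ug/mL, within 50 ug/mL to 400 ug/mL, and most likely to come back again only as a limit.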

Compound 3, concentration for 50% growth inhibition: > 100 ug/mL
Compound 3: only a limit was reported; the forecaster's own chance of this, stated with the estimate: 75%; the middle value does not contradict the limit.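

Among the compounds shown here, compound 1 and compound 3 both come back only as a limit, so no step between them can be read: the limit of > 100 ug/mL in this assay, at which 3 of the 3 values shown sit. The compounds shown leave open whether hydrogen in place of carboxymethyl changes anything in this assay, and at what concentration any of them would inhibit growth.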